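A few compounds are considered here, and "the series" means these few. Any claim that something is new, unique, unknown or untested is made for them only; others in the source may bear on it.

Measured so far in a functional assay on HCT-15 cells (Homo sapiens) for cytotoxicity, read by CCK-8 assay and cell counting, with a stated time of 2 days; a higher number here means a weaker inhibitor, a lower number a stronger inhibitor:
compound 1 `Oc1ccc(-c2cc(-c3cccc(Cl)c3)nc(-c3ccco3)c2)cc1` — 8020 nM
compound 2 `Oc1ccc(-c2cc(-c3ccco3)nc(-c3ccccc3Cl)c2)cc1` — 5460 nM
compound 3 `Oc1ccc(-c2cc(-c3ccc(Cl)cc3)nc(-c3cccs3)c2)cc1` — 6470 nM

Compound 3 stands second highest of the three numbers in this assay; its nearest neighbour is compound 2 and its furthest is compound 1, and both gaps sit within the scatter, so no order among the three is claimed.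

Compound 4 `Oc1ccc(-c2cc(-c3ccc(Cl)cc3)nc(-c3ccco3)c2)cc1` follows from compound 3 by one change: furan-2-yl in place of thiophen-2-yl on an aromatic carbon. Within the data shown here, the only single-point step measured, a 1.5-fold lower number from compound 1 to compound 2 (0.17 log units; within the scatter), concerns the chlorophenyl group and stayed within the scatter; it does not bear on the heteroaryl swap. Compounds 1 and 3 differ in two places and give no clean reading. Nothing measured therefore points to a shift beyond the scatter, and the step of a 1.0-fold higher number from compound 3 to compound 4 (0.00 log units; within the scatter) is expected to be small. Compound 4 is estimated at 6500 nM, between 3300 nM and 13000 nM.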

Compound 4, half-maximal inhibitory concentration: 7020 nM
Beside the measured number, compound 4's estimate is 1.1-fold (0.03 log units) below it; low and high end bracket the measured number.
By their numbers in this assay, from the lowest: compounds 2, 3, 4 and 1 (each within the scatter of the next).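

In this assay, among these compounds, the first direct reading at this position, furan-2-yl in place of thiophen-2-yl next to the ring nitrogen, gives a 1.1-fold higher number from compound 3 to compound 4 (0.04 log units; within the scatter) and leaves the number unmoved beyond the scatter. With furan-2-yl held, 4-chlorophenyl in place of 2-chlorophenyl gives a 1.3-fold higher number from compound 2 to compound 4 (0.11 log units; within the scatter) and 4-chlorophenyl in place of 3-chlorophenyl gives a 1.1-fold lower number from compound 1 to compound 4 (0.06 log units; within the scatter) so the three chlorophenyl placements are not separated. No supporting data bear on these results.

As far as these compounds go, whether an amine or a carboxylic acid in place of furan-2-yl would shift the number beyond the scatter remains open.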